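The source may report more compounds than this note shows. Statements on the series, on what has been measured and on what is new or still open speak of the compounds shown alone.

Compound 1 `O=C(Nc1cc(F)ccc1F)c1cc(=O)[nH]c2cc(Br)ccc12`: > 20000 nM, a limit of the assay.
Compound 2 `O=C(Nc1cccc(F)c1)c1cc(=O)[nH]c2cc(Br)ccc12`: 7300 nM.
Compound 3 `O=C(Nc1cccc(Cl)c1)c1cc(=O)[nH]c2cc(Br)ccc12`: > 20000 nM, a limit of the assay.

Within the data shown here, in a functional assay on KYSE-410 cells (Homo sapiens) for antiproliferative activity, read by MTT assay, with a stated time of 72 h (on this read-out lower numbers stand for stronger inhibition and higher numbers for weaker inhibition), compound 2 gives the only number measured; the other two values fall at the limit of > 20000 nM in this assay, at which 2 of the 3 values shown sit. Compound 4 `C#Cc1ccc2c(C(=O)Nc3cccc(F)c3)cc(=O)[nH]c2c1` differs from compound 2 in one place: ethynyl in place of bromo on an aromatic carbon. The two measured steps, an at least 2.7-fold lower number from compound 1 to compound 2 (0.43 log units; beyond the scatter) and an at least 2.7-fold higher number from compound 2 to compound 3 (0.43 log units; beyond the scatter), both alter the ring attached to the amide nitrogen and leave the bromo untouched, so neither bears on the exchange of bromo for ethynyl. Among the measured compounds shown here, with no measured step of this kind, no change beyond the scatter is expected. Compound 4 is therefore estimated at 6000 nM, with a wide range from 1500 nM to 20000 nM. That estimate corresponds to an expected step of a 1.2-fold lower number from compound 2 to compound 4 (0.09 log units; within the scatter).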

Compound 4, half-maximal inhibitory concentration: 9700 nM
The estimate for compound 4 lay 1.6-fold (0.21 log units) below the measured number; measured number inside the range.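

Among these compounds, this is the first look at the core's own ring rather than the ring on the amide nitrogen. In this assay, exchanging bromo for ethynyl gives a 1.3-fold higher number from compound 2 to compound 4 (0.12 log units; within the scatter), so at this position the two groups cannot be told apart, even though ethynyl brings in a triple bond and one more heavy atom. Nothing measured here explains why they behave alike. From the compounds shown here alone, whether an amine, a carboxylic acid or a longer chain at this place would shift the number remains open. So does whether the exchange gives the same result with a different ring on the amide nitrogen.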